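The compounds below may be only part of what the source reports. "The series", "measured", "known", "first", "only" and "open" are said of these compounds alone.

Measured in an ADME assay on HepG2 cells (Homo sapiens) for cytotoxicity, read by MTT assay, with a stated time of 72 h; a lower number here means that less compound is tolerated, a higher number that more compound is tolerated:
Compound 1 `O=[N+]([O-])c1c(CS(=O)(=O)c2ccccc2)nc2c(-c3ccc(CO)cc3)cc(Cl)cn12`: 13100 nM
Compound 2 `O=[N+]([O-])c1c(CS(=O)(=O)c2ccccc2)nc2c(-c3ccc(F)cc3F)cc(Cl)cn12`: > 7800 nM, a limit

Compound 2 has no number of its own and stands only at the limit of > 7800 nM in this assay, at which 1 of the 2 values shown sits. Compound 3 `O=[N+]([O-])c1c(CS(=O)(=O)c2ccccc2)nc2c(-c3cccc(C(F)(F)F)c3)cc(Cl)cn12` keeps the shared core of compound 2 and carries 3-(trifluoromethyl)phenyl in place of 2,4-difluorophenyl on an aromatic carbon. Within the data shown here, the one measured step that bears on this change is a step that the limit leaves unreadable from compound 1 to compound 2, which gives no size to carry over. Among the measured compounds shown here, the only firm number nearby is that of compound 1, at 13100 nM. No step beyond the scatter is therefore expected in this assay, in either direction. The estimated step is a step that the limit leaves unreadable from compound 2 to compound 3, and it is a rough expectation. For compound 3 the expected value is 11000 nM, with an estimated range of 4500 nM to 27000 nM.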

Compound 3, half-maximal cytotoxic concentration: > 12500 nM
Compound 3: only a limit was reported (the forecaster's own chance of this, stated with the estimate: 50%); middle value at least 1.1-fold (0.05 log units) from the limit.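

In this assay compound 3 gives > 12500 nM, which is a limit and not a number. No step can be read between compound 3 and either compound 1 or compound 2. The compounds shown leave open whether 3-(trifluoromethyl)phenyl in place of 2,4-difluorophenyl changes the tolerated concentration at all.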